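A few compounds are considered here, and "the series" means these few. Any claim that something is new, unique, unknown or untested is made for them only; others in the source may bear on it.

Measured so far in a functional assay on SK-OV-3 cells (Homo sapiens) for cytotoxicity; on this read-out higher numbers stand for an effect only at larger amounts of compound and lower numbers for an effect already at smaller amounts:
- compound 1 `C=CCCCCCC#CC#CC(O)CC(C)=O`: 3.85 ug/mL
- compound 2 `C=CCCCCCC#CC#C/C(O)=C\C(C)=O`: 3.52 ug/mL

Compound 2 gives the lowest of the two numbers in this assay, but compound 1 lies within the scatter of it, so the two values show no difference beyond repeat variation.

The next compound, compound 3 `C=CCCCCCC#CC#C/C(O)=C/C(C)=O`, has not yet been measured. It differs from compound 2 only as drawn: the two compounds have the same atoms and bonds and differ only in configuration as drawn: 1 of 1 stereo elements differ; a double bond is drawn E in compound 2 and Z in compound 3. Going by the values given here, no step between measured compounds is available to set the size of such a change, and the two measured values themselves span only the scatter. The expectation for this assay is therefore no step beyond the scatter, in either direction. For compound 3 the estimated value in this assay is 3.6 ug/mL, with a range from 1.8 ug/mL to 7.2 ug/mL. That estimate implies a step of a 1.0-fold higher number from compound 2 to compound 3 (0.01 log units; within the scatter) that stays within the usual scatter.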

Compound 3, concentration for half-maximal effect: 5.23 ug/mL
For compound 3 the middle estimate is 1.5-fold (0.16 log units) below the measured one; the measured number falls inside the stated range.
By their numbers in this assay, from the lowest: compounds 2, 1 and 3 (each within the scatter of the next).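

In this assay, going by these compounds alone, the configuration of this double bond is the first single-place change that can be read, and it gives a 1.5-fold higher number from compound 2 to compound 3 (0.17 log units; within the scatter). Drawing the double bond Z rather than E therefore does not separate the two compounds beyond repeat variation, so this configuration has not been shown to matter for the read-out. Any difference between this pair can be referred to one place only: the fact that compounds 2 and 3 differ only in the configuration as drawn

From the compounds shown here alone, it remains open whether a change elsewhere on the shared core, such as a carboxylic acid in place of the ketone or a longer chain, would give a step beyond the scatter in this assay. The compounds shown also leave open whether the configuration of this double bond would matter in any other read-out.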